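The source may hold more compounds than are shown below. What is called first, only, known or untested is meant among the compounds shown, and "the series" means these compounds.

- Compound 1 `CC(O)(CS(=O)(=O)c1ccc(F)cc1)C(=O)Nc1cccc(S(F)(F)(F)(F)F)c1`: 48800 nM
- Compound 2 `CC(O)(CS(=O)(=O)c1cccc(C(F)(F)F)c1)C(=O)Nc1cccc(S(F)(F)(F)(F)F)c1`: 37300 nM
- Compound 3 `CC(O)(CS(=O)(=O)c1ccc(OC(F)(F)F)cc1)C(=O)Nc1cccc(S(F)(F)(F)(F)F)c1`: 35600 nM

In a functional assay on DU-145 cells (Homo sapiens) for antiproliferative activity, read by propidium iodide staining, with a stated time of 96 h (on this read-out higher numbers stand for weaker inhibition and lower numbers for stronger inhibition), compound 3 is not truly separated from the other two: a 1.4-fold lower number from compound 1 to compound 3 (0.14 log units; within the scatter) and a 1.0-fold lower number from compound 2 to compound 3 (0.02 log units; within the scatter) both lie within the scatter. Compound 4 `CC(O)(CS(=O)(=O)c1ccccc1OC(F)(F)F)C(=O)Nc1cccc(S(F)(F)(F)(F)F)c1` has the same atoms joined differently, with 2-(trifluoromethoxy)phenyl in place of 4-(trifluoromethoxy)phenyl on a sulfonyl sulfur. For the measured compounds named here, no measured compound carries this group, so the evidence is indirect. Swapping the group on the sulfonyl sulfur has so far produced only small changes, namely a 1.3-fold lower number from compound 1 to compound 2 (0.12 log units; within the scatter) as well as the two steps above. No change beyond the scatter is therefore expected in this assay. The expected change is a 1.0-fold higher number from compound 3 to compound 4 (0.00 log units; within the scatter). Compound 4 is estimated at 36000 nM, with an expected range from 19000 nM to 65000 nM.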

Compound 4, half-maximal inhibitory concentration: 29100 nM
For compound 4 the middle estimate is 1.2-fold (0.09 log units) above the measured one; low and high end bracket the measured number.
By their numbers in this assay, from the lowest: compounds 4, 3, 2 and 1 (each within the scatter of the next).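

Unlike the earlier pairs, the step of a 1.2-fold lower number from compound 3 to compound 4 (0.09 log units; within the scatter) in this assay keeps the same trifluoromethoxy group and changes only where it sits on the ring, and this change of position does not separate the two compounds. The steps of a 1.3-fold lower number from compound 2 to compound 4 (0.11 log units; within the scatter) and a 1.7-fold lower number from compound 1 to compound 4 (0.22 log units; within the scatter) are also small, so all four aryl groups on the sulfonyl sulfur read alike here. No measurement shown gives a reason for this.

Still open, going by these compounds, is whether an aryl ring carrying an amine or a carboxylic acid, or a plain methyl on the sulfonyl sulfur, would shift the number beyond the scatter.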